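One Exchange on a Saturated Ring Carbon, Tried Again

The source may report more compounds than this note shows. Statements on the series, on what has been measured and on what is new or still open speak of the compounds shown alone.

Compound 3 `COc1ccc(C2CC(c3ccc(NC(=O)c4cc(Cl)ccc4OC)cc3)=NN2c2ccccc2)cc1` was tested in a functional assay on the whole organism (strain albino) with Rattus norvegicus as the target, read by paw edema, with stated times of 1 h and 4 h, at a dose of 50 mg/kg by the oral route (a lower number here means a weaker effect, a higher number a stronger effect of the compound at the dose given), where compound 3 gives 98%. Among the three measured compounds this is the second highest number, but its neighbours sit within the scatter on either side. Compound 2 `COc1ccc(Cl)cc1C(=O)Nc1ccc(C2=NN(C)C(c3ccccc3[N+](=O)[O-])C2)cc1` gives 99.5%, and compound 1 `COc1ccc(C2CC(c3ccc(NC(=O)c4cc(Cl)ccc4OC)cc3)=NN2C)cc1` gives 93.2%. The step of a number 4.8 percentage points higher from compound 1 to compound 3 (within the scatter) comes from phenyl in place of methyl on an amine nitrogen in a ring, the only thing that separates these two structures.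

Compound 4 `COc1ccc(Cl)cc1C(=O)Nc1ccc(C2=NN(c3ccccc3)C(c3ccccc3[N+](=O)[O-])C2)cc1` has not yet been measured. Its difference from compound 3 is 2-nitrophenyl in place of 4-methoxyphenyl on a saturated ring carbon. The same exchange has already been made once, between compound 1 and compound 2, where the step of a number 6.3 percentage points higher from compound 1 to compound 2 (within the scatter) did not rise above the scatter. Within the data shown here, that single example is the only guide here, and it points to no step beyond the scatter for compound 4 either. The expected step is therefore a number 1 percentage points higher from compound 3 to compound 4 (within the scatter), with compound 4 estimated at 99%, within a range from 92% to 100%.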

Compound 4, a percentage reported as activity, at one dose (the size of the read-out at that dose, not a potency): 88.4%
Compound 4: the middle estimate sits 10.6 percentage points above what was measured, and the stated range ends above it.
By their numbers in this assay, from the lowest: compounds 4, 1, 3 and 2 (each within the scatter of the next, the first and the last beyond it).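

In this assay, the exchange of 4-methoxyphenyl for 2-nitrophenyl on a saturated ring carbon does not carry over unchanged from one core to the other: the same change on two cores in this assay, a number 6.3 percentage points higher (within the scatter) from compound 1 to compound 2 and a number 9.6 percentage points lower (within the scatter) from compound 3 to compound 4, 15.9 percentage points apart, beyond the scatter of two such steps. The step of a number 9.6 percentage points lower from compound 3 to compound 4 (within the scatter) would not show this alone and the step of a number 11.1 percentage points lower from compound 2 to compound 4 (beyond the scatter) adds that the effect of phenyl in place of methyl on an amine nitrogen in a ring depends in turn on the group on the saturated ring carbon: the same change on two cores in this assay, a number 4.8 percentage points higher (within the scatter) from compound 1 to compound 3 and a number 11.1 percentage points lower (beyond the scatter) from compound 2 to compound 4, 15.9 percentage points apart, beyond the scatter of two such steps. Across these four compounds, then, the two changes do not simply add, and neither can be judged without the other.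

On these data alone, whether this dependence extends to an amine or a carboxylic acid on the saturated ring carbon, or to a longer chain on the ring nitrogen, stays open. Why the two changes depend on each other also remains unanswered.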